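Fluoro to iodo on an aromatic carbon

A few compounds are considered here, and "the series" means these few. Any claim that something is new, unique, unknown or untested is made for them only; others in the source may bear on it.

Measured so far:
Compound 1 `C/C(=N\NC(=S)Nc1cccc(F)c1)c1ccccn1`: 12 nM
Compound 2 `CC(=NNC(=S)Nc1cccc(F)c1)c1ccccn1`: 12 nM

Within the data shown here, in a functional assay on T98G cells (Homo sapiens) for cytotoxicity, read by MTT assay, with a stated time of 48 h (on this read-out higher numbers stand for weaker inhibition and lower numbers for stronger inhibition), compound 1 stands level with compound 2, the only other compound tested. Among the measured compounds shown here, the single measured step shows no change at the digits printed from compound 1 to compound 2 (within the scatter), and it concerns only (the fact that one of compounds 1 and 2 is drawn with a defined configuration and the other without, at the place where they differ). Compound 3 `C/C(=N\NC(=S)Nc1cccc(I)c1)c1ccccn1` is still to be tested in this assay. It carries iodo in place of fluoro on an aromatic carbon, meta to a large group (iodo in place of fluoro on an aromatic carbon). For the measured compounds named here, no measured step changes this substituent, so the data give neither a size nor a direction for the exchange, and no shift beyond the scatter is expected in this assay. The expected outcome is no change at the digits printed from compound 1 to compound 3 (within the scatter). This expectation starts from compound 1 at 12 nM. Compound 3 is estimated at 12 nM, with an expected range from 4 nM to 40 nM.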

Compound 3, half-maximal inhibitory concentration: 61 nM
Beside the measured number, compound 3's estimate is 5.1-fold (0.71 log units) below it, outside the stated range (above it).
By their numbers in this assay, from the lowest: compounds 1 and 2 (each within the scatter of the next); then compound 3.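

In this assay, this aromatic carbon, meta to a large group, proves sensitive to the substituent it carries: iodo in place of fluoro gives a 5.1-fold higher number from compound 1 to compound 3 (0.71 log units; beyond the scatter) and so weaker inhibition. Among these compounds, the earlier pair differed only in how a double bond was drawn and so said nothing about this position; this is the first change to move the number beyond the scatter. What is known here concerns that drawing alone and gives no reason for the shift seen with iodo.

Among the compounds shown here, two halogens define only one step, so they give no trend across the halogens, and whether chloro or bromo at this carbon would fall between compound 1 and compound 3 stays open. Equally open, going by these compounds, is how an amine, a methoxy group or a carboxylic acid would read at this place.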